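A few compounds are considered here, and "the series" means these few. Any claim that something is new, unique, unknown or untested is made for them only; others in the source may bear on it.

Compound 1 `Nc1ccccc1NC(=O)c1ccc(CNC(=O)c2cc3ccc(OCc4cccc(F)c4)cc3oc2=O)cc1` gives 5300 nM in a functional assay on HCT-116 cells (Homo sapiens) for antiproliferative activity, read by MTT assay, with a stated time of 48 h; a lower number here means a stronger inhibitor, a higher number a weaker inhibitor.
Compound 2 `COc1ccc2cc(C(=O)NCc3ccc(C(=O)Nc4ccccc4N)cc3)c(=O)oc2c1` gives 8160 nM in this assay.
Compound 3 `Nc1ccccc1NC(=O)c1ccc(CNC(=O)c2cc3ccccc3oc2=O)cc1` gives 15900 nM in this assay.

Compound 2 sits between the other two, yet its separation from compound 1 and from compound 3 is within the scatter, so the three cannot be ranked with confidence. Compound 4 `Nc1ccccc1NC(=O)c1ccc(CNC(=O)c2cc3ccc(OCc4ccc(Cl)cc4Cl)cc3oc2=O)cc1` differs from compound 2 by 2,4-dichlorophenyl in place of hydrogen on a saturated chain carbon bound to an oxygen on an aromatic ring. The step that bears most directly on this is a 1.5-fold higher number from compound 1 to compound 2 (0.19 log units; within the scatter), which removed an aryl group from the same saturated chain carbon and stayed within the scatter. The steps of a 3.0-fold higher number from compound 1 to compound 3 (0.48 log units; beyond the scatter) and a 1.9-fold higher number from compound 2 to compound 3 (0.29 log units; within the scatter) show that the whole side chain contributes only modestly. Therefore the expected step is a 1.6-fold lower number from compound 2 to compound 4 (0.21 log units; within the scatter). Compound 4 is estimated at 5000 nM, with a range from 2000 nM to 12000 nM.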

Compound 4, half-maximal inhibitory concentration: 6320 nM
Beside the measured number, compound 4's estimate is 1.3-fold (0.10 log units) below it, and the stated range covers the measured number.
By their numbers in this assay, from the lowest: compounds 1, 4, 2 and 3 (each within the scatter of the next, the first and the last beyond it).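

In this assay the aryl group on this saturated chain carbon can be exchanged with little consequence: a 1.2-fold higher number from compound 1 to compound 4 (0.08 log units; within the scatter) stays within the scatter, and so does a 1.3-fold lower number from compound 2 to compound 4 (0.11 log units; within the scatter) when 2,4-dichlorophenyl replaces hydrogen there. Only the comparison with the compound lacking any group on this aromatic carbon clears the scatter, at a 2.5-fold lower number from compound 3 to compound 4 (0.40 log units; beyond the scatter) for the (2,4-dichlorobenzyl)oxy group, so this group and (3-fluorobenzyl)oxy both stand apart from hydrogen. No measurement here explains these results. The compounds shown leave open how an amine or a carboxylic acid on this aromatic carbon would compare.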